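The compounds below may be only part of what the source reports. "The series", "measured", "known", "first", "only" and "open" are said of these compounds alone.

Working notes on the series. Compound 1 `COc1ccc(F)cc1N1C(=O)CSC1c1cccc(C(=O)NCCCCn2cccn2)c1` is the reference point. In a physicochemical assay for solubility, read by turbidimetry, measured as kinetic solubility, at pH 6.8 (on this read-out lower numbers stand for lower solubility and higher numbers for higher solubility), compound 1 gives 50000 nM, the higher of the two numbers in hand. Compound 2 `C#Cc1cccc(N2C(=O)CSC2c2cccc(C(=O)NCCCCc3ccccc3)c2)c1` gives 10000 nM in this assay, a lower number, and the gap between compound 1 and compound 2 lies beyond the usual scatter. Going by the values given here, no pair of measured compounds differs in a single place, so the series offers no measured step to lean on.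

Compound 3 `Cc1ccnc(N2C(=O)CSC2c2cccc(C(=O)NCCCCn3cccn3)c2)c1` has not yet been measured in this assay. It differs from compound 1 in one place 4-methylpyridin-2-yl in place of 5-fluoro-2-methoxyphenyl on an amide-type nitrogen in a ring: the 4-methylpyridin-2-yl, carrying one six-membered aromatic ring with 1 hetero atom, takes the position of the 5-fluoro-2-methoxyphenyl on an amide-type nitrogen in a ring. Among the compounds with values here, with no step of this type recorded, the expected step is a 1.3-fold higher number from compound 1 to compound 3 (0.11 log units; within the scatter), small and if anything upward, within or just beyond the scatter. Compound 3 is therefore estimated at 65000 nM in this assay, with a range from 25000 nM to 160000 nM.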

Compound 3, solubility: 50000 nM
Estimate against measurement, compound 3: 1.3-fold (0.11 log units) above; low and high end bracket the measured number.
By their numbers in this assay, from the lowest: compound 2; then compounds 1 and 3 (each within the scatter of the next).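

In this assay, going by these compounds alone, the first measured step at this position reads no change at the digits printed from compound 1 to compound 3 (within the scatter), with 4-methylpyridin-2-yl in place of 5-fluoro-2-methoxyphenyl on an amide-type nitrogen in a ring. This exchange replaces a six-membered aromatic ring of carbon only with one carrying a hetero atom, and it removes the methoxy and fluoro substituents, yet the read-out does not separate the two groups. No measurement on hand offers an explanation for this result.

On these data alone, whether a group such as an amine or a carboxylic acid at this position would move the read-out beyond the scatter remains open. Within the data shown here, it is also open whether the same exchange would read alike with a different amide side chain, such as the one in compound 2.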